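A few compounds are considered here, and "the series" means these few. Any claim that something is new, unique, unknown or untested is made for them only; others in the source may bear on it.

Measured so far:
Compound 1, `COc1cccc(CN2C(=O)CN(C(=O)c3cc4cc(OC)ccc4[nH]3)C[C@@H]2CCc2ccccc2)c1`: 0.12 h
Compound 2, `COc1ccc2[nH]c(C(=O)N3CC(=O)N(Cc4ccccc4)[C@@H](COC(C)(C)C)C3)cc2c1`: 0.278 h
Compound 3, `COc1ccc2[nH]c(C(=O)N3CC(=O)N(Cc4ccccc4)[C@@H](N4CCC(Cc5ccccc5)CC4)C3)cc2c1`: 0.597 h

All three values come from an ADME assay on microsomes from liver (Homo sapiens) for metabolic stability, with a stated time of 30 min, tested at 1 uM; a higher number here means that the compound lasts longer, a lower number that the compound disappears faster. Within this small set compound 2 stands second highest of the three numbers: compound 3 gives a higher number and compound 1 a lower one, and both of those gaps lie beyond the usual scatter of repeated measurements. Going by the values given here, no pair among the measured compounds differs in only one place, so no single structural step can be read directly from the numbers; they show only that the three share a core and differ in more than one way at once.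

Compound 4, `COc1ccc2[nH]c(C(=O)N3CC(=O)N(Cc4ccccc4)[C@@H](CN4CCc5ccccc5C4)C3)cc2c1`, has not yet been measured. It differs from compound 2 in one place: 1,2,3,4-tetrahydroisoquinolin-2-yl in place of tert-butoxy on a saturated chain carbon bound to a saturated ring carbon. Without a measured step of the same kind, the expectation can rest only on the spread of the three values. Compound 3 gives 0.597 h, the highest number here, and compound 1 gives 0.12 h, the lowest, so the known range is narrow. Compound 4 is expected to give 0.4 h, within a range from 0.15 h to 1 h. The expected step of a 1.4-fold higher number from compound 2 to compound 4 (0.16 log units; within the scatter) is estimated to point upward but to stay modest, close to the edge of the scatter.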

Compound 4, half-life: 0.617 h
Compound 4: middle estimate off by 1.5-fold (0.19 log units), on the low side, within the range that was stated.
By their numbers in this assay, from the lowest: compound 1; then compound 2; then compounds 3 and 4 (each within the scatter of the next).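

Going by these compounds alone, this is the first single change at this position that can be read directly, and in this assay it gives a 2.2-fold higher number from compound 2 to compound 4 (0.35 log units; beyond the scatter), a modest step that lies beyond the scatter. It shows that this saturated chain carbon, bound to a saturated ring carbon, can carry 1,2,3,4-tetrahydroisoquinolin-2-yl with its 10 heavy atoms in place of tert-butoxy with its 5, and that the compound then lasts longer rather than disappearing faster. Nothing available here explains the rise or ties it to any one part of the new group.

The compounds shown do not separate the contribution of the ring nitrogen from that of the added aromatic ring, which a simple dimethylamino group or a morpholine on the same chain carbon would begin to address. They also leave open how a hydroxyl group, a carboxylic acid or a longer chain at this place would behave in this assay, so a single step cannot yet define a trend for this position.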